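Removing a Methoxy Group: Cytotoxicity Estimate for Compound 4

The source may report more compounds than this note shows. Statements on the series, on what has been measured and on what is new or still open speak of the compounds shown alone.

Of the compounds shown here, three sharing a common scaffold have been tested in a functional assay on HCT-15 cells (Homo sapiens) for cytotoxicity, read by MTT assay, with a stated time of 72 h; a lower number here means a stronger inhibitor, a higher number a weaker inhibitor. Compound 1 `COc1ccc(/C=C/C(=O)c2ccccc2F)c(OC)c1` gives 55.9 nM in this assay, compound 2 `COc1ccc(C(=O)/C=C/c2cc(OC)c(OC)c(OC)c2)c(F)c1` gives 50.5 nM, and compound 3 `COc1ccc(C(=O)/C=C/c2ccc(OC)cc2OC)c(F)c1` gives 72.2 nM. All three values lie within the scatter of one another, so no ordering among them can be claimed. The difference between the cores of compound 2 and compound 3 is not broken down here.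

Compound 3 and compound 1 differ in one place: hydrogen in place of methoxy on an aromatic carbon. This change produced a 1.3-fold lower number from compound 3 to compound 1 (0.11 log units; within the scatter).

Compound 4 `COc1cc(/C=C/C(=O)c2ccc(OC)cc2F)cc(OC)c1` has not yet been measured. It differs from compound 2 by hydrogen in place of methoxy on an aromatic carbon. This is the same kind of change as that from compound 3 to compound 1, but the surroundings differ: in compound 1 the place is meta to a fluoro group and para to a large group, whereas in compound 4 it is ortho to two methoxy groups and para to a large group.

Because the earlier step was a 1.3-fold lower number from compound 3 to compound 1 (0.11 log units; within the scatter), compound 4 is expected to show a 1.1-fold lower number from compound 2 to compound 4 (0.05 log units; within the scatter) in this assay, giving an estimated 45 nM, with a likely range from 20 nM to 110 nM.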

Compound 4, half-maximal inhibitory concentration: 55.3 nM
For compound 4 the middle estimate is 1.2-fold (0.09 log units) below the measured one, within the range that was stated.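

Putting hydrogen in place of methoxy on an aromatic carbon gave, in this assay, a 1.1-fold higher number from compound 2 to compound 4 (0.04 log units; within the scatter). Set beside the same change on the other core, the result gives no sign that the core matters: the same change on two cores in this assay, a 1.3-fold lower number (0.11 log units; within the scatter) from compound 3 to compound 1 and a 1.1-fold higher number (0.04 log units; within the scatter) from compound 2 to compound 4, 1.4-fold (0.15 log units) apart, within the scatter of two such steps. This shows only that, on these two cores, the loss of one methoxy group left the number within the scatter; it does not show that the change has a fixed size or direction, since neither step can be told from the noise, and two pairs with different surroundings at the changed place cannot establish a rule for the rest of the series.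

Among these compounds, in these compounds, hydrogen is the only group that takes the place of methoxy, so how an amine, a hydroxyl group or a longer alkoxy chain at that place would read remains open. Also open, from the compounds shown here alone, is whether any change at that place moves the number beyond the scatter at all.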